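The source may report more compounds than this note shows. Statements on the series, on what has been measured and on what is new or still open speak of the compounds shown alone.

Measured so far, in an assay for inhibition of HSP60/HSP10 (Homo sapiens), with a stated time of 60 min; a lower number here means a stronger inhibitor, a higher number a weaker inhibitor:
compound 1 `COc1ccccc1C(=O)Nc1ccc(Sc2nc3ccccc3s2)c(Cl)c1` — > 100000 nM, a limit of the assay
compound 2 `O=C(Nc1ccc(Sc2nc3ccccc3s2)c(Cl)c1)c1ccccc1O` — > 100000 nM, a limit of the assay
compound 3 `O=C(Nc1cccc(Cl)c1)c1cc(Br)ccc1O` — > 100000 nM, a limit of the assay

Compound 2 sits at a limit in this assay. Compound 1 likewise sits at a limit. The change from compound 2 to compound 1 is methyl in place of hydrogen on an oxygen on an aromatic ring, and the step that the two limits leave unreadable from compound 2 to compound 1 cannot be read because of the limit of > 100000 nM in this assay, at which 3 of the 3 values shown sit. Compound 3 also sits at a limit in this assay. The difference between the core of compound 3 and the core of compound 2 is not broken down here.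

Compound 4 `COc1ccc(Br)cc1C(=O)Nc1cccc(Cl)c1` is not yet measured. It differs from compound 3 by methyl in place of hydrogen on an oxygen on an aromatic ring, the same change that turns compound 2 into compound 1. Since the earlier step was left unreadable by the limits, the expectation for compound 4 rests on compound 3 alone: with compound 3 giving > 100000 nM, compound 4 is expected to remain near the limit, a step that the limit leaves unreadable from compound 3 to compound 4. Compound 4 is thus estimated at 150000 nM in this assay, most likely again as a limit rather than a number.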

Compound 4, half-maximal inhibitory concentration: > 100000 nM
Compound 4: a limit, no number; the forecaster's own chance of this, stated with the estimate: 80%; the middle value does not contradict the limit.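

In this assay compound 4 gives > 100000 nM, a limit of the assay and not a number, so the step from compound 3 to compound 4 cannot be read: the limit of > 100000 nM in this assay, at which 4 of the 4 values shown sit.

The compounds shown leave open whether hydroxy to methoxy has any effect on inhibition, and what structure would give a measurable value.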